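From chloro to methyl at the assay limit

This account rests on a few compounds, and the source may have more. Where it says the series, first, only, none or still open, it means among the compounds named here.

In a functional assay on HCT-116 cells (Homo sapiens) for inhibition, read by MTT assay, with a stated time of 48 h (a lower number here means a stronger inhibitor, a higher number a weaker inhibitor), compound 1 `O=C1N/C(=N\Cc2ccccc2)S/C1=C1/CCNC(=O)c2[nH]ccc21` gives 49700 nM. Compound 2 `O=C1N/C(=N\Cc2ccc(C(F)(F)F)cc2)S/C1=C1/CCNC(=O)c2[nH]ccc21` reads > 100000 nM, which is a limit and not a number. Compound 3 `O=C1N/C(=N\Cc2ccc(Cl)cc2)S/C1=C1/CCNC(=O)c2[nH]ccc21` reads > 100000 nM, which is likewise only a limit. Compound 3 therefore stands at the limit of > 100000 nM in this assay, at which 2 of the 3 values shown sit.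

Compound 4 `Cc1ccc(C/N=C2\NC(=O)/C(=C3\CCNC(=O)c4[nH]ccc43)S2)cc1` differs from compound 3 by a single change, methyl in place of chloro on an aromatic carbon, para to a large group. For the measured compounds named here, the only swap between two such groups so far is a step that the two limits leave unreadable from compound 2 to compound 3, which gives no usable size. Two other measured steps bear on the change, an at least 2.0-fold higher number from compound 1 to compound 3 (0.30 log units; that floor lies within the scatter) and an at least 2.0-fold higher number from compound 1 to compound 2 (0.30 log units; that floor lies within the scatter), and on their strength compound 4 is expected to stay weak in this assay, with no step beyond the scatter from compound 3. The step expected is an at least 1.1-fold lower number from compound 3 to compound 4 (0.07 log units; that floor lies within the scatter). For compound 4 the estimated value is 85000 nM, with an expected range from 40000 nM to 160000 nM.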

Compound 4, half-maximal inhibitory concentration: 4760 nM
For compound 4 the middle estimate is 18-fold (1.25 log units) above the measured one; measured number below the stated range.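

In this assay, the aromatic carbon para to a large group turns out to be sensitive to the choice of group: methyl in place of chloro gives an at least 21-fold lower number from compound 3 to compound 4 (1.32 log units; beyond the scatter), and methyl in place of trifluoromethyl gives an at least 21-fold lower number from compound 2 to compound 4 (1.32 log units; beyond the scatter). Substitution here therefore need not leave a compound weak, since methyl in place of hydrogen gives a 10-fold lower number from compound 1 to compound 4 (1.02 log units; beyond the scatter), which makes compound 4 the strongest of the four. The step between the other two substituted compounds cannot be read, and the steps from them to compound 4 have only a floor, as their values are limits: the limit of > 100000 nM in this assay, at which 2 of the 4 values shown sit.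

The compounds shown leave open whether the gain is particular to methyl or extends to a longer chain such as ethyl, to methoxy or to an amine at this carbon. They also leave open whether methyl on another carbon of the same ring would give a similar step.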